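The source may report more compounds than this note shows. Statements on the series, on what has been measured and on what is new or still open speak of the compounds shown alone.

Going by the values given here, compound 2 `FC(F)(F)c1ccc(CO/N=C2/C(c3c[nH]c4ccccc34)=Nc3ccccc32)cc1` gives the lower of the two numbers measured so far in a functional assay on T-24 cells (Homo sapiens) for cytotoxicity, read by MTT assay, with a stated time of 2 days (on this read-out higher numbers stand for weaker inhibition and lower numbers for stronger inhibition), at 18900 nM, and its neighbour compound 1 `Fc1ccc(CO/N=C2/C(c3c[nH]c4ccccc34)=Nc3ccccc32)cc1` gives 23100 nM in this assay. Among the compounds with values here, the step of a 1.2-fold lower number from compound 1 to compound 2 (0.09 log units; within the scatter) is the only measured step and it lies within the scatter, so the two compounds cannot be ordered. Compound 3 `Fc1ccc(CO/N=C2/C(c3c[nH]c4ccccc34)=Nc3ccccc32)c(Cl)c1` differs from compound 2 by 2-chloro-4-fluorophenyl in place of 4-(trifluoromethyl)phenyl on a saturated chain carbon bound to an oxygen on an unsaturated carbon. Within the data shown here, the change restores the fluoro of compound 1 and adds a chloro, and no measured step covers the added chloro; the one step available, which swapped fluoro and trifluoromethyl, moved the number by less than the scatter. On that basis the step of a 1.1-fold higher number from compound 2 to compound 3 (0.05 log units; within the scatter) is expected to be small and of no settled direction. Compound 3 is therefore estimated to give about 21000 nM in this assay, in a range from 7000 nM to 60000 nM.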

Compound 3, half-maximal inhibitory concentration: 20000 nM
Compound 3: middle estimate off by 1.1-fold (0.02 log units), on the high side; low and high end bracket the measured number.
By their numbers in this assay, from the lowest: compounds 2, 3 and 1 (each within the scatter of the next).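

In this assay, chloro in place of hydrogen on an aromatic carbon gives a 1.2-fold lower number from compound 1 to compound 3 (0.06 log units; within the scatter), and exchanging the whole 4-(trifluoromethyl)phenyl for 2-chloro-4-fluorophenyl gives a 1.1-fold higher number from compound 2 to compound 3 (0.02 log units; within the scatter), both within the scatter. Going by these compounds alone, this is the first reading of a chloro at this place, and with it the three aryl groups on the saturated chain carbon all stand within the scatter of one another, so the three compounds cannot be ordered. No evidence is available that bears on this result. All three groups shown are halogen-bearing phenyls, so it remains open whether an amine or a carboxylic acid on that ring would give a number beyond the scatter. Going by these compounds, it is equally open whether a longer chain between the oxygen and the ring would do so.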